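The source may hold more compounds than are shown below. What is called first, only, known or untested is meant among the compounds shown, and "the series" means these compounds.

Measured so far:
Compound 1 `Cc1ncc2cnnc(S)n12` — > 48000 nM
Compound 2 `CCCc1ncc2cnnc(S)n12` — > 48000 nM
Compound 3 `Cc1nc(C)n2c(S)nncc12` — > 48000 nM

In a functional assay for inhibition, with Homo sapiens as the target (on this read-out lower numbers stand for stronger inhibition and higher numbers for weaker inhibition), compound 1 stands at a limit of the assay, not at a measured number. Compound 2 and compound 3 likewise reached only a limit, so all three values sit at the limit of > 48000 nM in this assay, at which 3 of the 3 values shown sit. Compound 4 `CSc1nncc2cnc(C)n12` differs from compound 1 by methyl in place of hydrogen on a sulfur. Of the measured steps, a step that the two limits leave unreadable from compound 1 to compound 2 and a step that the two limits leave unreadable from compound 1 to compound 3 change other places on the shared core, and neither can be read in size, so none bears on a change at the sulfur. With every value at the limit, no step beyond the scatter can be expected in this assay. Compound 4 is therefore estimated at 48000 nM, ranging from 15000 nM to 150000 nM, most likely as another limit, the expected step being a number no higher from compound 1 to compound 4 (the limit leaves the size open).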

Compound 4, half-maximal inhibitory concentration: > 48000 nM
Compound 4: no number, only a limit (the forecaster's own chance of this, stated with the estimate: 85%); the middle value sits exactly at the limit.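

Compound 1 and compound 4 both reach only a limit, so the step from hydrogen to methyl on the sulfur cannot be read in size: the limit of > 48000 nM in this assay, at which 4 of the 4 values shown sit.

The compounds shown leave open whether any change on the shared core gives a readable inhibition value.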